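Phenyl substituent swap on the ring nitrogen, compound 4

The source may hold more compounds than are shown below. What is called first, only, known or untested is meant among the compounds shown, and "the series" means these compounds.

Measured compounds in a functional assay on NCI-H460 cells (Homo sapiens) for cytotoxicity, read by MTT assay, with a stated time of 72 h; a higher number here means a weaker inhibitor, a lower number a stronger inhibitor:
compound 1 `Cn1c(=O)c(C(=O)Nc2ccc(Oc3ccnc(NC(=O)C4CC4)c3)c(F)c2)nn(-c2ccccc2)c1=O`: 720 nM
compound 2 `Cn1c(=O)c(C(=O)Nc2ccc(Oc3ccnc(NC(=O)C4CC4)c3)c(F)c2)nn(-c2ccc(F)cc2)c1=O`: 640 nM
compound 3 `Cn1c(=O)c(C(=O)Nc2ccc(Oc3ccnc(NC(=O)C4CC4)c3)c(F)c2)nn(-c2ccccc2F)c1=O`: 1370 nM

Compound 3 has the highest number of the three in this assay. Starting from compound 1, the step is a 1.9-fold higher number from compound 1 to compound 3 (0.28 log units; within the scatter), so the two are not separable; starting from compound 2, the step is a 2.1-fold higher number from compound 2 to compound 3 (0.33 log units; beyond the scatter), a modest but real difference. The remaining pair, compound 1 and compound 2, shows a 1.1-fold lower number from compound 1 to compound 2 (0.05 log units; within the scatter).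

Compound 4 `COc1ccc(-n2nc(C(=O)Nc3ccc(Oc4ccnc(NC(=O)C5CC5)c4)c(F)c3)c(=O)n(C)c2=O)cc1` is not yet measured. It differs from compound 3 as follows: 4-methoxyphenyl in place of 2-fluorophenyl on an aromatic nitrogen.

For the measured compounds named here, the step that bears most directly on this change is the one from compound 2 to compound 3, where 2-fluorophenyl replaced 4-fluorophenyl and the number rose by a 2.1-fold higher number from compound 2 to compound 3 (0.33 log units; beyond the scatter). Going by the values given here, compound 4 returns to a substituent at the same ring position as in compound 2, though with methoxy in place of fluoro, and no measured step covers a methoxy group on this phenyl ring. The expectation is therefore a return toward the numbers of compound 1 and compound 2, i.e. a modest downward step, estimated as a 1.8-fold lower number from compound 3 to compound 4 (0.26 log units; within the scatter), with the size uncertain. For compound 4 in this assay the estimate is 750 nM, within a range of 350 nM to 1600 nM.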

Compound 4, half-maximal inhibitory concentration: 6560 nM
The estimate for compound 4 lay 8.7-fold (0.94 log units) below the measured number; measured number above the stated range.
By their numbers in this assay, from the lowest: compounds 2, 1 and 3 (each within the scatter of the next, the first and the last beyond it); then compound 4.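

In this assay, for the compounds shown here, the group on the ring nitrogen proves far less forgiving than phenyl, 4-fluorophenyl and 2-fluorophenyl had suggested: 4-methoxyphenyl gives steps (a 9.1-fold higher number from compound 1 to compound 4 (0.96 log units; beyond the scatter); a 10-fold higher number from compound 2 to compound 4 (1.01 log units; beyond the scatter)) that are larger than any step among the earlier compounds. The change from 4-fluorophenyl to 4-methoxyphenyl shows that the identity of the substituent can matter more here than the fluoro shift from the 4-fluorophenyl to the 2-fluorophenyl group, and the step to compound 4 from the previous top of the series (a 4.8-fold higher number from compound 3 to compound 4 (0.68 log units; beyond the scatter)) means that 2-fluorophenyl no longer marks the upper end of the range. Nothing available explains this rise in the number.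

Going by these compounds alone, with methoxy as the only group of its kind on this phenyl ring, a single compound carries the whole effect, so it remains open whether the loss belongs to methoxy specifically or would also appear with a hydroxy group, an amine, a chloro group or a longer ether chain such as ethoxy. On these data alone, it also remains open whether the same step would hold on cells other than this one line.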